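The source may hold more compounds than are shown below. What is called first, only, known or untested is meant among the compounds shown, and "the series" means these compounds.

Measured so far:
compound 1, `CCCCN(C)c1cc(C(F)(F)F)ccc1CNC(=O)C(C)c1ccc(NS(C)(=O)=O)c(F)c1`, in an assay on CHO cells for antagonist activity at transient receptor potential cation channel subfamily V member 1 (Homo sapiens), read by FLIPR; on this read-out higher numbers stand for weaker inhibition and lower numbers for stronger inhibition: 1.2 nM
compound 2, `CC(C(=O)NCc1ccc(C(F)(F)F)cc1N1CCC(C)(C)CC1)c1ccc(NS(C)(=O)=O)c(F)c1`, in this assay: 1.3 nM

Among the measured compounds shown here, compound 2 and compound 1 lie within the scatter of each other in this assay, the only step so far being a 1.1-fold higher number from compound 1 to compound 2 (0.03 log units; within the scatter). Compound 2 therefore stands at a number that is not separable from compound 1 on the data in hand.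

Compound 3, `CC(C(=O)NCc1ccc(C(F)(F)F)cc1N1CCN(c2ccccc2)CC1)c1ccc(NS(C)(=O)=O)c(F)c1`, has not been measured. It differs from compound 2 in one place: 4-phenylpiperazin-1-yl in place of 4,4-dimethylpiperidin-1-yl on an aromatic carbon. For the measured compounds named here, the one measured step that bears on this is the exchange of one nitrogen-linked group for another at the same aromatic carbon, a 1.1-fold higher number from compound 1 to compound 2 (0.03 log units; within the scatter), which stayed within the scatter. On that basis no step beyond the scatter is expected in this assay from compound 2 to compound 3, in either direction; the step is estimated as a 1.2-fold higher number from compound 2 to compound 3 (0.09 log units; within the scatter). For compound 3 the expected value in this assay is 1.6 nM, with a range of 0.5 nM to 6 nM.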

Compound 3, inhibition constant: 2 nM
Beside the measured number, compound 3's estimate is 1.3-fold (0.10 log units) below it, within the range that was stated.
By their numbers in this assay, from the lowest: compounds 1, 2 and 3 (each within the scatter of the next).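

In this assay, the aromatic carbon ortho to a large group and meta to a trifluoromethyl group now carries 4-phenylpiperazin-1-yl, which adds an aromatic ring of carbon only and a second ring nitrogen, with a 1.5-fold higher number from compound 2 to compound 3 (0.19 log units; within the scatter) and a 1.7-fold higher number from compound 1 to compound 3 (0.22 log units; within the scatter). Across butyl(methyl)amino, 4,4-dimethylpiperidin-1-yl and 4-phenylpiperazin-1-yl, the three compounds therefore cannot be separated at this position, and this now holds for a group of 12 heavy atoms as well as one of 8. Nothing measured here accounts for why the read-out stays within the scatter across these groups.

Open, going by these compounds, is whether morpholin-4-yl, a primary amine or a piperazine bearing a carboxylic acid at this aromatic carbon would stay within the same scatter in this assay. Also open, on these data alone, is how a carbon-linked chain or an ether oxygen at this place would compare with the three nitrogen-linked groups.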